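This account rests on a few compounds, and the source may have more. Where it says the series, first, only, none or still open, it means among the compounds named here.

Three stereoisomers of one scaffold have been measured in a physicochemical assay for solubility, in phosphate buffer; a lower number here means a less soluble compound, a higher number a more soluble compound. Compound 1 `C[C@@H]1CN([C@H](C)CO)C(=O)c2cccc(NC(=O)c3ccncc3)c2O[C@H]1CN(C)Cc1ccc(Oc2ccccc2)cc1` gives 1000 nM, the lowest of the three numbers. Compound 2 `C[C@@H]1CN([C@@H](C)CO)C(=O)c2cccc(NC(=O)c3ccncc3)c2O[C@@H]1CN(C)Cc1ccc(Oc2ccccc2)cc1` gives 87000 nM, and compound 3 `C[C@H]1CN([C@@H](C)CO)C(=O)c2cccc(NC(=O)c3ccncc3)c2O[C@H]1CN(C)Cc1ccc(Oc2ccccc2)cc1` gives 93000 nM. The step of an 87-fold higher number from compound 1 to compound 2 (1.94 log units; beyond the scatter) and the step of a 93-fold higher number from compound 1 to compound 3 (1.97 log units; beyond the scatter) are both large, while the step of a 1.1-fold higher number from compound 2 to compound 3 (0.03 log units; within the scatter) lies within the scatter, so compounds 2 and 3 cannot be told apart on this read-out.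

Compound 4 `C[C@H](CO)N1C[C@H](C)[C@H](CN(C)Cc2ccc(Oc3ccccc3)cc2)Oc2c(NC(=O)c3ccncc3)cccc2C1=O` is not yet measured in this assay. Compared with compound 1, (the two compounds have the same atoms and bonds and differ only in configuration as drawn: 1 of 3 stereo elements differ; a stereocentre at a saturated ring carbon is drawn R in compound 1 and S in compound 4). For the measured compounds named here, each of the two measured steps from compound 1 also involved a change at a saturated ring carbon, together with a second change, and each gave a large rise in solubility; compound 4 carries only the single change at the ring carbon, so those steps bear on it only partly. Inverting one centre of a molecule of this kind can alter how the solid packs, and both measured departures from compound 1 went upward, so a rise beyond the scatter is expected, though smaller and less certain than the measured ones. For compound 4 the expected step is a 15-fold higher number from compound 1 to compound 4 (1.18 log units; beyond the scatter), giving an estimated value of 15000 nM, with a range from 2000 nM to 90000 nM.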

Compound 4, solubility: 98000 nM
The estimate for compound 4 lay 6.5-fold (0.82 log units) below the measured number; the whole stated range lies below it.
By their numbers in this assay, from the lowest: compound 1; then compounds 2, 3 and 4 (each within the scatter of the next).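

In this assay, for the compounds shown here, inverting one saturated ring carbon is enough on its own to give a large step, a 98-fold higher number from compound 1 to compound 4 (1.99 log units; beyond the scatter), so the second change present in the earlier steps from compound 1 was not needed for a rise of this size, and the step can be tied to that single centre because of this: the fact that compounds 1 and 4 differ only in the configuration as drawn. Inverting the saturated chain carbon on its own gives no readable shift, with a 1.1-fold higher number from compound 3 to compound 4 (0.02 log units; within the scatter) lying within the scatter, and this comparison isolates that one centre because of this: the fact that compounds 3 and 4 differ only in the configuration as drawn. Inverting all three stereocentres also leaves the read-out within the scatter, at a 1.1-fold higher number from compound 2 to compound 4 (0.05 log units; within the scatter), a comparison of two mirror images that rests on this: the fact that compounds 2 and 4 differ only in the configuration as drawn.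

The compounds shown do not tell why compound 1 alone sits at 1000 nM, nor whether inverting only its saturated chain carbon would change that number. They also leave open whether the large gap between compound 1 and compound 4 would persist with a carboxylic acid or an amine in place of the hydroxyl group.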